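Dichlorophenyl in place of pyridinyl: tolerability notes

The source may report more compounds than this note shows. Statements on the series, on what has been measured and on what is new or still open speak of the compounds shown alone.

Compound 1 `Cc1nc(-c2cccnc2)sc1-c1nnc(-c2ccncc2)o1` is the reference point in an ADME assay on HeLa cells (Homo sapiens) for cytotoxicity, read by MTT assay; a higher number here means that more compound is tolerated, a lower number that less compound is tolerated. In this assay compound 1 gives > 100 ug/mL, which is a limit of the assay and not a number. Compound 2 `Cc1ccccc1-c1nnc(-c2sc(-c3cccnc3)nc2C)o1` carries 2-methylphenyl in place of pyridin-4-yl on an aromatic carbon. In this assay compound 2 gives > 100 ug/mL, again a limit and not a number. The step that the two limits leave unreadable from compound 1 to compound 2 is therefore not readable in size, both values sitting at the limit of > 100 ug/mL in this assay, at which 2 of the 2 values shown sit. Compound 3 `Cc1nc(-c2cccnc2)sc1-c1nnc(-c2cccc(Cl)c2Cl)o1` is not yet measured in this assay; it differs from compound 1 by 2,3-dichlorophenyl in place of pyridin-4-yl on an aromatic carbon. Within the data shown here, the one measured step touches the same aromatic carbon but gives no size, so no direction beyond the scatter can be read for this assay. Compound 3 is expected to sit near 90 ug/mL, with a range from 40 ug/mL to 200 ug/mL. The expected step of an at least 1.1-fold lower number from compound 1 to compound 3 (0.04 log units; that floor lies within the scatter) is thus estimated to stay within what the scatter can hide.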

Compound 3, half-maximal cytotoxic concentration: > 100 ug/mL
Compound 3: no number, only a limit; the forecaster's own chance of this, stated with the estimate: 55%; at least 1.1-fold (0.04 log units) between middle value and limit.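

In this assay compound 3 gives > 100 ug/mL as a limit of the assay and not a number. Among these compounds, no step among compound 1, compound 2 and compound 3 can be read in size: the limit of > 100 ug/mL in this assay, at which 3 of the 3 values shown sit. The compounds shown leave open whether pyridin-4-yl, 2-methylphenyl and 2,3-dichlorophenyl differ at all in how much compound is tolerated.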